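A few compounds are considered here, and "the series" means these few. Any claim that something is new, unique, unknown or untested is made for them only; others in the source may bear on it.

In a functional assay on HeLa cells (Homo sapiens) for cytotoxicity, read by MTT assay (a lower number here means a stronger inhibitor, a higher number a weaker inhibitor), compound 2 `CC(C)=CC[C@@H](OC(=O)c1ccco1)C1=CC(=O)c2c(O)ccc(O)c2C1=O` gives 80300 nM, the highest of the three numbers shown, though all three lie within the scatter of one another: compound 1 `CC(C)=CC[C@@H](OC(=O)CCO)C1=CC(=O)c2c(O)ccc(O)c2C1=O` gives 67600 nM and compound 3 `CCC(CO[C@H](CC=C(C)C)C1=CC(=O)c2c(O)ccc(O)c2C1=O)OC(C)=O` gives 44000 nM, with a 1.2-fold higher number from compound 1 to compound 2 (0.07 log units; within the scatter) and a 1.8-fold lower number from compound 2 to compound 3 (0.26 log units; within the scatter). Compound 4 `CC(=O)OC(C)CO[C@H](CC=C(C)C)C1=CC(=O)c2c(O)ccc(O)c2C1=O` differs from compound 2 by 2-acetoxypropyl in place of (furan-2-yl)carbonyl on an oxygen on a saturated carbon. The step that bears most on this is a 1.8-fold lower number from compound 2 to compound 3 (0.26 log units; within the scatter), where a 2-acetoxybutyl likewise replaced (furan-2-yl)carbonyl on an oxygen on a saturated carbon; a 1.5-fold lower number from compound 1 to compound 3 (0.19 log units; within the scatter) points the same way, and nothing here moves beyond the scatter. Compound 4 is therefore expected to show a 1.7-fold lower number from compound 2 to compound 4 (0.22 log units; within the scatter), a small move toward a lower number at most. Compound 4 is estimated at 48000 nM in this assay, with a range from 25000 nM to 95000 nM.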

Compound 4, half-maximal inhibitory concentration: 40100 nM
The estimate for compound 4 lay 1.2-fold (0.08 log units) above the measured number, and the stated range covers the measured number.
By their numbers in this assay, from the lowest: compounds 4, 3, 1 and 2 (each within the scatter of the next).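

In this assay, 2-acetoxypropyl in place of (furan-2-yl)carbonyl swaps a five-membered aromatic ring for no ring at the same heavy-atom count, yet the result stays within the scatter (a 2.0-fold lower number from compound 2 to compound 4 (0.30 log units; within the scatter)). Hydrogen in place of methyl on the chain (a 1.1-fold lower number from compound 3 to compound 4 (0.04 log units; within the scatter)) and 2-acetoxypropyl in place of (2-hydroxyethyl)carbonyl (a 1.7-fold lower number from compound 1 to compound 4 (0.23 log units; within the scatter)) likewise stay within it, so no change on this oxygen among these four compounds exceeds the scatter. Nothing shown explains this flat picture. On these data alone, whether an amine or a carboxylic acid on this oxygen would move the number beyond the scatter remains open.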